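Cytotoxicity notes on a shared-core hydrazone series

This account rests on a few compounds, and the source may have more. Where it says the series, first, only, none or still open, it means among the compounds named here.

Of the compounds shown here, three on a shared core have been measured in an ADME assay on HEL cells (Homo sapiens) for cytotoxicity; a higher number here means that more compound is tolerated, a lower number that less compound is tolerated. Compound 1 `O=C(COc1cccc2ccccc12)N/N=C/c1ccc(O)cc1` gives 20 ug/mL in this assay. Compound 3 `O=C(COc1cccc2ccccc12)N/N=C/c1ccccc1O` gives 20 ug/mL, and compound 2 `C/C(=N\NC(=O)COc1cccc2ccccc12)c1cccc([N+](=O)[O-])c1` gives 20 ug/mL. For the measured compounds named here, the only single-point step among them, no change at the digits printed from compound 1 to compound 3 (within the scatter), moves nothing at the digits read; with that, compound 2 stands level with both compound 1 and compound 3, its nearest neighbour being compound 1 and its furthest compound 3, neither separated from it beyond the scatter.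

Compound 4 `C/C(=N\NC(=O)COc1cccc2ccccc12)c1ccc(O)cc1O` remains to be measured. It differs from compound 2 in one place: 2,4-dihydroxyphenyl in place of 3-nitrophenyl on a carbon with a double bond to nitrogen. Going by the values given here, no measured step exchanges this pair of groups, so the step from compound 1 to compound 3 is the only one that bears on it: there one hydroxyphenyl was swapped for another on the same carbon and the reading held. The three values sit at one level across two hydroxyphenyl groups and a nitrophenyl, which argues for no step beyond the scatter in this assay. Accordingly compound 4 is expected to give 20 ug/mL in this assay, within 10 ug/mL to 40 ug/mL, which means an expected step of no change at the digits printed from compound 2 to compound 4 (within the scatter).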

Compound 4, minimum cytotoxic concentration: > 100 ug/mL
Compound 4 ended at the assay's limit; the forecaster's own chance of this, stated with the estimate: 10%; middle value at least 5.0-fold (0.69 log units) away from the limit.
By their numbers in this assay, from the lowest: compounds 1, 2 and 3 (each within the scatter of the next). At a limit, above all of these: compound 4.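

In this assay, for the compounds shown here, the place on a carbon with a double bond to nitrogen proves able to move the reading: the exchange of 3-nitrophenyl for 2,4-dihydroxyphenyl gives an at least 5.0-fold higher number from compound 2 to compound 4 (0.69 log units; beyond the scatter), whereas the only earlier step, no change at the digits printed from compound 1 to compound 3 (within the scatter), had left the reading unmoved. Going by these compounds alone, the level shared by compounds 1, 2 and 3 therefore does not hold for every aromatic group at this place, and compound 4 is the one compound that goes against it. The reading of compound 4 is a limit of the assay and not a number, so the step has a floor but no measured size: the limit of > 100 ug/mL in this assay, at which 1 of the 4 values shown sits.

The compounds shown do not separate the departure of 3-nitrophenyl from the arrival of 2,4-dihydroxyphenyl, so it stays open which side of the exchange carries the step, and whether both hydroxyl groups are needed for it. Also open, as far as these compounds go, is whether an aminophenyl or a carboxyphenyl group on the same carbon would read with compound 4 or at the level of compounds 1, 2 and 3.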